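Aryl replacement on the shared core: compound 3 to compound 4

A few compounds are considered here, and "the series" means these few. Any claim that something is new, unique, unknown or untested is made for them only; others in the source may bear on it.

Compound 1 `CCSc1sc(-n2nc(C)c(Cc3ccccc3[N+](=O)[O-])c2C(=O)O)nc1-c1ccc(Cl)c(Cl)c1` gives 59000 nM in a functional assay on BJAB cells (Homo sapiens) for antiproliferative activity, with a stated time of 4 days; on this read-out lower numbers stand for an effect already at smaller amounts and higher numbers for an effect only at larger amounts of compound. Compound 2 `COc1ccc(C)cc1-c1c(C)nn(-c2nc(-c3ccc(Cl)c(Cl)c3)c(SC(C)C)s2)c1C(=O)O` gives 9500 nM in this assay, and compound 3 `COc1cncc(-c2c(C)nn(-c3nc(-c4ccc(Cl)c(Cl)c4)c(SC(C)C)s3)c2C(=O)O)c1` gives 21000 nM. Compound 3 thus stands second highest of the three numbers, between compound 2 and compound 1. For the measured compounds named here, the only single-site step in the set is a 2.2-fold higher number from compound 2 to compound 3 (0.34 log units; beyond the scatter), a modest one. Compound 4 `CC(=O)Nc1ccc(-c2c(C)nn(-c3nc(-c4ccc(Cl)c(Cl)c4)c(SC(C)C)s3)c2C(=O)O)cc1` differs from compound 3 as follows: 4-acetamidophenyl in place of 5-methoxypyridin-3-yl on an aromatic carbon. Going by the values given here, no measured step covers this exact exchange; the step at the same place, a 2.2-fold higher number from compound 2 to compound 3 (0.34 log units; beyond the scatter), gives a scale for an aryl swap but no direction. For compound 4 a step of about a 1.2-fold lower number from compound 3 to compound 4 (0.07 log units; within the scatter) is therefore expected, close to the scatter. Compound 4 is estimated at 18000 nM, with a range from 6000 nM to 55000 nM.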

Compound 4, half-maximal effective concentration: 139000 nM
Compound 4: the middle estimate sits 7.7-fold (0.89 log units) below what was measured, and the stated range ends below it.
By their numbers in this assay, from the lowest: compound 2; then compound 3; then compound 1; then compound 4.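

Aryl exchange at this position can shift the number much further than the step first seen here (a 2.2-fold higher number from compound 2 to compound 3 (0.34 log units; beyond the scatter)): in this assay, 4-acetamidophenyl gives the largest numbers of the three aryl groups, with a 6.6-fold higher number from compound 3 to compound 4 (0.82 log units; beyond the scatter) and a 15-fold higher number from compound 2 to compound 4 (1.17 log units; beyond the scatter). The position therefore does not accept every aryl group equally, and 4-acetamidophenyl is the least favourable of the three. No measurement shown accounts for this rise.

From the compounds shown here alone, compound 3 and compound 4 differ in both the ring hetero atom and the substituent, so the contribution of each remains open. A 4-aminophenyl group at this position would show whether the acetyl part of the acetamido group matters.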